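Hydroxymethyl for methylcarbamoyl on a shared aryl core

A few compounds are considered here, and "the series" means these few. Any claim that something is new, unique, unknown or untested is made for them only; others in the source may bear on it.

Of the compounds shown here, two have been measured in an in vitro ADME assay on microsomes from liver (Homo sapiens) for metabolic stability, tested at 1 uM; a lower number here means that the compound disappears faster, a higher number that the compound lasts longer. Compound 1 `Cc1cc(CCC#N)cc(C)c1Oc1cc(Nc2ccc(C#N)cc2)c(N)cc1C(N)=O` gives 0.7 h, and compound 2 `CNC(=O)c1cc(N)c(Nc2ccc(C#N)cc2)cc1Oc1c(C)cc(CCC#N)cc1C` gives 0.928 h. Compound 2 stands highest of the two numbers, though the step of a 1.3-fold higher number from compound 1 to compound 2 (0.12 log units; within the scatter) lies within the scatter, so the two values are not separable.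

Compound 3 `Cc1cc(CCC#N)cc(C)c1Oc1cc(Nc2ccc(C#N)cc2)c(N)cc1CO` differs from compound 2 in one place: hydroxymethyl in place of methylcarbamoyl on an aromatic carbon. Among the measured compounds shown here, no measured step among the known compounds touches this change; the only step available, methyl in place of hydrogen on an amide-type nitrogen, produced a 1.3-fold higher number from compound 1 to compound 2 (0.12 log units; within the scatter) and thus gives little guidance. Without a comparable change to lean on, the expected step of a 1.2-fold lower number from compound 2 to compound 3 (0.06 log units; within the scatter) is set close to no change beyond the scatter, with a wide range to reflect the uncertainty. Compound 3 is therefore estimated at 0.8 h, between 0.3 h and 2 h.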

Compound 3, half-life in the Homo sapiens assay: 0.348 h
Compound 3: middle estimate off by 2.3-fold (0.36 log units), on the high side; the range from low to high includes it.
By their numbers in the Homo sapiens assay, from the lowest: compounds 3, 1 and 2 (each within the scatter of the next, the first and the last beyond it).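

In the Homo sapiens assay, hydroxymethyl in place of methylcarbamoyl on this aromatic carbon gives the only step among these compounds that lies beyond the scatter, a 2.7-fold lower number from compound 2 to compound 3 (0.43 log units; beyond the scatter), whereas methyl on the amide-type nitrogen did not separate the two amides. Measured against the unmethylated amide, the change is less clear, with a 2.0-fold lower number from compound 1 to compound 3 (0.30 log units; within the scatter). In a physicochemical assay for solubility, with a stated time of 4 h, at pH 7.4 (on this read-out lower numbers stand for lower solubility and higher numbers for higher solubility), compound 2 gives 8.28 ug/mL and compound 3 gives 18.8 ug/mL, a 2.3-fold higher number from compound 2 to compound 3 (0.36 log units; beyond the scatter), so this change lowers the number in the Homo sapiens assay while raising the number in the physicochemical assay.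

The compounds shown leave open whether another group on this aromatic carbon, such as aminomethyl or methoxymethyl, would keep the higher number of compound 3 in the physicochemical assay without its lower number in the Homo sapiens assay.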